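Carbamoyl for Hydroxy on the Benzyl Ester Compound

The compounds below may be only part of what the source reports. "The series", "measured", "known", "first", "only" and "open" are said of these compounds alone.

Measured compounds in a functional assay on the whole organism (Tail, strain ICR) with Mus musculus as the target, in the tail flick test, with a stated time of 30 min, at a dose of 25 umol/kg by the oral route; a higher number here means a stronger effect of the compound at the dose given, a lower number a weaker effect:
compound 1 `O=C(CN(c1nc(Cl)nc2[nH]cnc12)C1CC1)N[C@@H](CO)C(=O)OCc1ccccc1`: 31.9%
compound 2 `O=C(CN(c1nc(Cl)nc2[nH]cnc12)C1CC1)N[C@@H](CO)C(=O)O`: 38.7%
compound 3 `NC(=O)CC[C@H](NC(=O)CN(c1nc(Cl)nc2[nH]cnc12)C1CC1)C(=O)O`: 33.1%

Compound 1 gives the lowest of the three numbers in this assay, but its nearest neighbour is compound 3, only a little higher and within the scatter, and even compound 2, the furthest, sits higher only within the scatter. The three compounds therefore share one level of effect at this dose and cannot be ranked.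

Compound 4 `NC(=O)C[C@H](NC(=O)CN(c1nc(Cl)nc2[nH]cnc12)C1CC1)C(=O)OCc1ccccc1` has not yet been measured. It differs from compound 1 by carbamoyl in place of hydroxy on a saturated chain carbon, two bonds along the chain from an amide-type nitrogen and a carbonyl carbon. Among the compounds with values here, two measured steps bear on this. The first is a number 5.6 percentage points lower from compound 2 to compound 3 (within the scatter), a change of the same kind at the same place on the free acid. The second is a number 6.8 percentage points higher from compound 1 to compound 2 (within the scatter), which shows that keeping or removing the benzyl ester on this core made no difference beyond the scatter. Neither step moved the read-out beyond the scatter, so the expected step is a number 1.9 percentage points lower from compound 1 to compound 4 (within the scatter), that is, no change beyond the scatter in either direction.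

The estimate for compound 4 in this assay is therefore 30%, with a range from 18% to 42%.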

Compound 4, a percentage reported as activity, at one dose (the size of the read-out at that dose, not a potency): 24.4%
Compound 4: the middle estimate sits 5.6 percentage points above what was measured; measured number inside the range.
By their numbers in this assay, from the lowest: compounds 4, 1, 3 and 2 (each within the scatter of the next, the first and the last beyond it).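

In this assay, the exchange of hydroxy for carbamoyl on a saturated chain carbon, two bonds along the chain from an amide-type nitrogen and a carbonyl carbon, has now been read on the benzyl ester itself, and it gives a number 7.5 percentage points lower from compound 1 to compound 4 (within the scatter). The earlier compounds had shown a change at this place only on the free acid, so this result adds that the benzyl ester also accepts carbamoylmethyl in place of hydroxymethyl, with three heavy atoms entering where one leaves, and the read-out stays within the scatter of compound 1. The data offer no explanation for this step, and none of the information at hand bears on it.

From the compounds shown here alone, it stays open whether an amine or a carboxylic acid at this place on the benzyl ester, or a longer chain carrying the carbamoyl group, would keep the read-out at this level. Going by these compounds, it also stays open how these compounds would compare across a range of doses, as the read-out at one dose gives the size of the effect and not a potency.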